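From fluoro to trifluoromethoxy: compound 3 to compound 4

The source may report more compounds than this note shows. Statements on the series, on what has been measured and on what is new or still open speak of the compounds shown alone.

In a functional assay on NCI-H460 cells (Homo sapiens) for inhibition, read by MTT assay, with a stated time of 24 h, tested at 100 ug/mL (on this read-out lower numbers stand for less inhibition of growth and higher numbers for more inhibition of growth at the one concentration tested), compound 3 (`O=C(CCCCC(S)CCS)Nc1ccc(F)cc1`) gives 41.6%, within the scatter of compound 2 (`O=C(CCCCC(S)CCS)Nc1ccc(Cl)cc1`) at 40.9%. Compound 1 (`O=C(CCCCC1CCSS1)Nc1ccc(OC(F)(F)F)cc1`) gives 83%, the highest of the three and beyond the scatter of both.

Compound 4 (`O=C(CCCCC(S)CCS)Nc1ccc(OC(F)(F)F)cc1`) differs from compound 3 at one place: trifluoromethoxy in place of fluoro on an aromatic carbon. Trifluoromethoxy replaces fluoro on an aromatic carbon, para to a large group.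

Among the measured compounds shown here, the one measured step at this place, a number 0.7 percentage points higher from compound 2 to compound 3 (within the scatter), is within the scatter, but it exchanges only fluoro for chloro. Compound 1 also carries trifluoromethoxy, on a different core, and its 83% cannot separate the group from that core.

A modest upward step a number 11.4 percentage points higher from compound 3 to compound 4 (beyond the scatter) is therefore expected in this assay. For compound 4 the estimated value is 53%, with an expected range of 37% to 75%.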

Compound 4, percent growth inhibition at one concentration: 65.1%
The estimate for compound 4 lay 12.1 percentage points below the measured number; the range from low to high includes it.
By their numbers in this assay, from the lowest: compounds 2 and 3 (each within the scatter of the next); then compound 4; then compound 1.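

In this assay, trifluoromethoxy separates from the halogens on the shared core: a number 23.5 percentage points higher from compound 3 to compound 4 (beyond the scatter) and a number 24.2 percentage points higher from compound 2 to compound 4 (beyond the scatter) while fluoro and chloro stay within the scatter of each other. With trifluoromethoxy held in place, the ring-free group in place of the five-membered non-aromatic ring gives a number 17.9 percentage points lower from compound 1 to compound 4 (beyond the scatter) and so shows that the chain end also matters here.

As far as these compounds go, whether an amine or a carboxylic acid at this aromatic carbon would follow trifluoromethoxy or the halogens stays open, as does whether the ring step holds with fluoro or chloro. No measurement shown bears on why these steps arise.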